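Swapping trifluoromethyl for chloro on a urea-bearing ring

The compounds below may be only part of what the source reports. "The series", "measured", "known", "first", "only" and "open" are said of these compounds alone.

Measured so far in a functional assay on UACC-257 cells (Homo sapiens) for inhibition, read by sulforhodamine B assay, with a stated time of 48 h; on this read-out higher numbers stand for weaker inhibition of growth and lower numbers for stronger inhibition of growth:
- compound 1, `O=C(Nc1cccc(-n2cc(-c3ccncc3)c(-c3ccc(Cl)c(O)c3)n2)c1)Nc1ccc(Cl)c(Cl)c1`, gives 3160 nM
- compound 2, `COc1cc(-c2nn(-c3cccc(NC(=O)Nc4cccc(C(F)(F)F)c4)c3)cc2-c2ccncc2)ccc1Cl`, gives 2310 nM
- compound 3, `COc1cc(-c2nn(-c3cccc(NC(=O)Nc4ccc(Cl)c(C(F)(F)F)c4)c3)cc2-c2ccncc2)ccc1Cl`, gives 6030 nM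

Compound 3 gives the highest of the three numbers, but its gap to compound 1 lies within the usual scatter; only its gap to compound 2 lies beyond it, as the step of a 2.6-fold higher number from compound 2 to compound 3 (0.42 log units; beyond the scatter) shows. Among the compounds with values here, that step is the one measured change of this set, and it adds a group rather than exchanging one.

Compound 4, `COc1cc(-c2nn(-c3cccc(NC(=O)Nc4ccc(Cl)c(Cl)c4)c3)cc2-c2ccncc2)ccc1Cl`, is not yet measured. It differs from compound 3 by chloro in place of trifluoromethyl on an aromatic carbon. Within the data shown here, no measured step in this set makes the same exchange, so the expectation rests on indirect hints. Compound 1 carries the same 3,4-dichlorophenyl group as compound 4 on a different core, and compound 1 sits at 3160 nM, within the scatter of compound 3. Compound 4 is therefore expected to land near compound 3 or somewhat lower, a step of about a 1.5-fold lower number from compound 3 to compound 4 (0.18 log units; within the scatter). The estimate for compound 4 in this assay is 4000 nM, with a range from 1500 nM to 11000 nM.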

Compound 4, concentration for total growth inhibition: 3110 nM
For compound 4 the middle estimate is 1.3-fold (0.11 log units) above the measured one; the measured number falls inside the stated range.
By their numbers in this assay, from the lowest: compounds 2, 4, 1 and 3 (each within the scatter of the next, the first and the last beyond it).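

In this assay the exchange of trifluoromethyl for chloro at this ring carbon gives a 1.9-fold lower number from compound 3 to compound 4 (0.29 log units; within the scatter), so the two groups cannot be told apart at this position. Within the data shown here, the other new readings are also small: the change of aryl group on the urea nitrogen gives a 1.3-fold higher number from compound 2 to compound 4 (0.13 log units; within the scatter), and methyl in place of hydrogen on the oxygen, a change the earlier steps did not cover, gives a 1.0-fold lower number from compound 1 to compound 4 (0.01 log units; within the scatter). Nothing here offers an explanation for these readings.

Going by these compounds, it remains open whether a different group at this ring carbon, such as a nitrile, a methoxy group or an amine, would give a step beyond the scatter. A carboxylic acid or a longer alkyl chain on the oxygen of the other ring is equally untested by the compounds shown.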